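The source may report more compounds than this note shows. Statements on the series, on what has been measured and on what is new or still open speak of the compounds shown alone.

Working notes on the series. Compound 1 `CCCCCCOc1cccc(O)c1C(=O)/C=C/c1ccc(O)cc1`, compound 2 `CCCCCCCCOc1cccc(O)c1C(=O)/C=C/c1ccc(O)cc1` and compound 3 `CCCCCCCCCCCCCCCCOc1cccc(O)c1C(=O)/C=C/c1ccc(O)cc1` share one core and differ only in the saturated chain on an oxygen on an aromatic ring. In an ADME assay on RAW264.7 cells (Mus musculus) for cytotoxicity, read by MTT assay (a higher number here means a weaker inhibitor, a lower number a stronger inhibitor), compound 1 gives > 30000 nM, which is a limit. Compound 2 gives > 30000 nM, also a limit. Compound 3 gives > 30000 nM, again a limit, so its place in the series is known only as a limit. The whole set so far comes down to the limit of > 30000 nM in this assay, at which 3 of the 3 values shown sit.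

The next compound is compound 4 `CCCCCCCCCCCCCCCCCCOc1cccc(O)c1C(=O)/C=C/c1ccc(O)cc1`, and the change is ethyl in place of hydrogen on a saturated chain carbon, ten or more bonds along the chain from an oxygen on an aromatic ring. Within the data shown here, three measured steps bear on it, each a lengthening of the same chain: a step that the two limits leave unreadable from compound 1 to compound 2, a step that the two limits leave unreadable from compound 1 to compound 3 and a step that the two limits leave unreadable from compound 2 to compound 3. They offer no size to carry over, and none of these lengthenings has yet produced a number in this assay. No step beyond the scatter is therefore expected in this assay, in either direction, and a further limit is the likely report. The estimated step is a step that the limit leaves unreadable from compound 3 to compound 4. Compound 4 is expected at 40000 nM, with an estimated range of 25000 nM to 80000 nM.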

Compound 4, half-maximal inhibitory concentration: > 30000 nM
Compound 4: no number, only a limit; the forecaster's own chance of this, stated with the estimate: 90%; the middle value is on the limit's open side.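

The steps from compound 1, compound 2 and compound 3 to compound 4 in this assay cannot be read, as each joins two limits. The series still comes down to one limit: the limit of > 30000 nM in this assay, at which 4 of the 4 values shown sit.

The compounds shown leave open where any of the four truly lies beyond that limit, and whether the length of the chain affects the read-out at all.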